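Pyrazole in Place of Phenyl on the Shared Core

The compounds below may be only part of what the source reports. "The series", "measured", "known", "first", "only" and "open" are said of these compounds alone.

Of the compounds shown here, three built on one shared core have been measured in an in vitro assay on HEK385-7 cells for displacement of a labelled ligand from prostaglandin D2 receptor 2 (Homo sapiens); on this read-out higher numbers stand for weaker inhibition and lower numbers for stronger inhibition. Compound 1 `O=C(O)Cc1sc(C(c2ccc(F)cc2)c2ccc(F)cc2)nc1-c1ccccc1` gives 16 nM in this assay, the lowest of the three numbers. Compound 3 `O=C(O)Cc1sc(C(c2ccccc2)c2ccc(Cl)cc2)nc1-c1ccc(Cl)cc1` gives 45 nM, a number that lies beyond the scatter above that of compound 1, and compound 2 `O=C(O)Cc1sc(C(c2ccccc2)c2ccccc2)nc1-c1ccc(C(F)(F)F)cc1` gives 1100 nM, the highest of the three and far beyond the scatter from compound 1. No two of these compounds differ in one place only, so no single step can be read from them; they show only that the aryl group carried on the core goes together with widely differing numbers.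

Compound 4 `O=C(O)Cc1sc(C(c2ccc(F)cc2)c2ccc(F)cc2)nc1-c1cn[nH]c1` has not yet been measured. It differs from compound 1 in one place: 1H-pyrazol-4-yl in place of phenyl on an aromatic carbon. Among the compounds with values here, no measured pair shows this kind of exchange, so its size cannot be taken from the data. The numbers of compound 2 and compound 3 show that what sits in that position on the core matters greatly, so a shift beyond the scatter is expected, more likely toward a higher number. The step of a 3.8-fold higher number from compound 1 to compound 4 (0.57 log units; beyond the scatter) is expected to be of moderate size. Compound 4 is estimated at 60 nM, with a range from 15 nM to 300 nM.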

Compound 4, half-maximal inhibitory concentration: 16 nM
The estimate for compound 4 lay 3.8-fold (0.57 log units) above the measured number; the range from low to high includes it.
By their numbers in this assay, from the lowest: compounds 1 and 4 (each within the scatter of the next); then compound 3; then compound 2.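

In this assay, replacing phenyl with 1H-pyrazol-4-yl on the aromatic carbon next to the ring nitrogen gives no change at the digits printed from compound 1 to compound 4 (within the scatter), so this position tolerates a five-membered aromatic ring with 2 hetero atoms in place of a six-membered aromatic ring of carbon only, with no shift in the number. The earlier compounds shown here differed in more than one place, so the wide spread of their numbers could not be tied to this position, and this single exchange now shows that a change of ring here need not move the number at all. Nothing among the available data explains why the number holds across this exchange.

As far as these compounds go, it remains open whether the same holds for other groups at this position, such as a pyridine ring, a 1-methylpyrazole or a phenyl ring carrying an amine. From the compounds shown here alone, it also remains open whether 1H-pyrazol-4-yl would behave the same way if the two fluorophenyl groups of the large group on the core were replaced by unsubstituted phenyl rings.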